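Amine substituent variation on a shared core

This account rests on a few compounds, and the source may have more. Where it says the series, first, only, none or still open, it means among the compounds named here.

compound 1 `OCCC(NC1CCN(CCCc2c[nH]c3ccc(-n4cnnc4)cc23)CC1)c1ccccc1`: 5.1 nM
compound 2 `CN(Cc1ccsc1)C1CCN(CCCc2c[nH]c3ccc(-n4cnnc4)cc23)CC1`: 4.2 nM

Both compounds were read in an assay on CHO cells for agonist activity at 5-hydroxytryptamine receptor 1D (Homo sapiens), read by GTPgammaS binding; on this read-out lower numbers stand for an effect already at smaller amounts and higher numbers for an effect only at larger amounts of compound. Compound 2 stands at one end of the pair; the step of a 1.2-fold lower number from compound 1 to compound 2 (0.08 log units; within the scatter) lies within the scatter, so the two are not separable. Compound 3 `CC(C)=CCN(C)C1CCN(CCCc2c[nH]c3ccc(-n4cnnc4)cc23)CC1` differs from compound 2 by 2-methylprop-1-en-1-yl in place of thiophen-3-yl on a saturated chain carbon bound to an amine nitrogen. Going by the values given here, the only measured step at this position, a 1.2-fold lower number from compound 1 to compound 2 (0.08 log units; within the scatter), exchanged the entire amine substituent without effect beyond the scatter, so a further exchange here is expected to leave this assay essentially unchanged. Compound 3 is therefore estimated at 5 nM, range 2 nM to 13 nM. The expected step is a 1.2-fold higher number from compound 2 to compound 3 (0.08 log units; within the scatter).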

Compound 3, half-maximal effective concentration: 1.8 nM
Beside the measured number, compound 3's estimate is 2.8-fold (0.44 log units) above it, outside the stated range (below it).
By their numbers in this assay, from the lowest: compound 3; then compounds 2 and 1 (each within the scatter of the next).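

In this assay, going by these compounds alone, the amine substituent is no longer without effect: 3-methylbut-2-en-1-yl in place of (thiophen-3-yl)methyl gives (a 2.3-fold lower number from compound 2 to compound 3 (0.37 log units; beyond the scatter)), the first step beyond the scatter. Methyl(3-methylbut-2-en-1-yl)amino in place of (3-hydroxy-1-phenylpropyl)amino gives a step of similar standing (a 2.8-fold lower number from compound 1 to compound 3 (0.45 log units; beyond the scatter)), while compound 1 and compound 2 remain inseparable. Nothing at hand explains either step.

Open, on these data alone, is whether the double bond matters, which a saturated 3-methylbutyl group on the same nitrogen would test. Also open, as far as these compounds go, is whether an ethyl group could replace the methyl on that amine nitrogen.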